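A few compounds are considered here, and "the series" means these few. Any claim that something is new, unique, unknown or untested is made for them only; others in the source may bear on it.

Three related compounds have been tested in a functional assay on REH cells (Homo sapiens) for cytotoxicity, read by resazurin assay, with a stated time of 72 h (a lower number here means a stronger inhibitor, a higher number a weaker inhibitor), and a fourth awaits its result. Compound 1 `COc1cc(OC)c(C(C)=O)c(OC)c1` carries three methoxy groups on its core. In this assay compound 1 gives > 20000 nM, which is a limit of the assay rather than a number. Compound 2 `COCOc1cc(OC)cc(OC)c1C(C)=O` differs from compound 1 in one place: hydrogen in place of methoxy on a saturated chain carbon bound to an oxygen on an aromatic ring. In this assay compound 2 gives > 20000 nM, again a limit. As far as these compounds go, because both results are limits, the step that the two limits leave unreadable from compound 2 to compound 1 cannot be read, and its size stays unknown.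

Compound 3 `COCOc1cc(OCOC)c(C(=O)/C=C/c2ccccc2)c(OCOC)c1` has a different core, and the difference between its core and that of compound 2 is not broken down here. In this assay compound 3 gives > 20000 nM, once more a limit. The striking point so far is the limit of > 20000 nM in this assay, at which 3 of the 3 values shown sit, so none of the three measured compounds has shown a readable potency.

Compound 4 `COCOc1cc(OC)c(C(=O)/C=C/c2ccccc2)c(OCOC)c1` is the compound still to be measured. It differs from compound 3 by the same change seen between compound 2 and compound 1: hydrogen in place of methoxy on a saturated chain carbon bound to an oxygen on an aromatic ring. Since that change left no readable step between compound 2 and compound 1, the expected step that the limit leaves unreadable from compound 3 to compound 4 rests on nothing more than the weak showing of every measured compound. Compound 4 is therefore expected to give about 25000 nM in this assay, most likely again as a limit, with a plausible range from 8000 nM to 60000 nM.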

Compound 4, half-maximal inhibitory concentration: 9200 nM
Estimate against measurement, compound 4: 2.7-fold (0.43 log units) above; measured number inside the range.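

In this assay, as far as these compounds go, putting hydrogen in place of methoxy on a saturated chain carbon bound to an oxygen on an aromatic ring, which turns a methoxymethoxy group into a methoxy group, gives an at least 2.1-fold lower number from compound 3 to compound 4 (0.33 log units; beyond the scatter), so on this core the change brings a modest but real move towards a stronger inhibitor, and its true size is unknown, as one end of the step is a limit of the assay rather than a number. The same change on the core of compound 2 cannot be read, because both of its results are limits, and the series as a whole gives very little to compare: the limit of > 20000 nM in this assay, at which 3 of the 4 values shown sit. The change therefore shows a readable effect on one core only, and these compounds neither show that it carries over to another core nor rule that out.

From the compounds shown here alone, it remains open how the number in this assay would move if a further methoxymethoxy group of compound 4 were turned into methoxy as well. The compounds shown also leave open what an amine, a carboxylic acid or a longer chain in that same place would do on either core.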